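Swapping tert-butyl for nitro on the aryl ring

A few compounds are considered here, and "the series" means these few. Any claim that something is new, unique, unknown or untested is made for them only; others in the source may bear on it.

Compound 1 `CC(C)c1cccc(C(C)C)c1NC(=O)NCC1(c2ccc(C(C)(C)C)cc2)CCCC1` is tested in an assay on microsomes for inhibition of acyl-CoA:cholesterol acyltransferase (Oryctolagus cuniculus) (a lower number here means a stronger inhibitor, a higher number a weaker inhibitor), where compound 1 gives 63 nM. For the measured compounds named here, the only other measured compound, compound 2 `CC(C)c1cccc(C(C)C)c1NC(=O)NCC1(c2ccc(OCc3ccccc3)cc2)CCCC1`, gives 34 nM in this assay, so compound 1 stands alongside compound 2 without a gap beyond the scatter, and the step of a 1.9-fold lower number from compound 1 to compound 2 (0.27 log units; within the scatter) is the whole spread among the measured numbers. Compound 3 `CC(C)c1cccc(C(C)C)c1NC(=O)NCC1(c2ccc([N+](=O)[O-])cc2)CCCC1` is not yet measured; its change from compound 1 is nitro in place of tert-butyl on an aromatic carbon. Going by the values given here, the one measured step at the same place exchanges the tert-butyl for another group and stays within the scatter, but no measured step shows what nitro, which brings two hydrogen-bond acceptors where tert-butyl brought none, does here. The number for compound 3 is therefore expected to move only modestly, by about a 1.9-fold higher number from compound 1 to compound 3 (0.28 log units; within the scatter), with a slight weakening as the likelier side. Compound 3 is estimated at 120 nM, within a range from 40 nM to 400 nM.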

Compound 3, half-maximal inhibitory concentration: 131 nM
Compound 3: the middle estimate sits 1.1-fold (0.04 log units) below what was measured, within the range that was stated.
By their numbers in this assay, from the lowest: compounds 2 and 1 (each within the scatter of the next); then compound 3.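

In this assay, this position now shows a change beyond the scatter: nitro in place of tert-butyl gives a 2.1-fold higher number from compound 1 to compound 3 (0.32 log units; beyond the scatter), and nitro in place of benzyloxy gives a 3.9-fold higher number from compound 2 to compound 3 (0.59 log units; beyond the scatter). The earlier pair could not show this, as compound 1 and compound 2 lie within the scatter of each other, whereas compound 3 has the highest number of the three, so the group on this aromatic carbon does matter, though only modestly so far. Nothing measured here accounts for the rise.

The compounds shown leave open how an amine, a carboxylic acid or a methoxy group on this aromatic carbon would compare. They also leave open whether nitro would give a step of this size on another core.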